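Cyclobutyl for propyl on a non-cytotoxic triazole amide

The compounds below may be only part of what the source reports. "The series", "measured", "known", "first", "only" and "open" are said of these compounds alone.

Compound 1 `CCCn1nc(C(=O)N[C@H]2COc3ccccc3N(C)C2=S)nc1Cc1ccccc1` was tested in a toxicity assay on HT-29 cells (Homo sapiens) for cytotoxicity; on this read-out higher numbers stand for lower toxicity in this test and lower numbers for higher toxicity in this test. In this test compound 1 shows only a limit, > 100000 nM. Compound 2 `CN1C(=S)[C@@H](NC(=O)c2nc(Cc3ccccc3)n(CCC(F)(F)F)n2)COc2ccccc21` also reaches only a limit, > 100000 nM. Compound 3 `CN1C(=S)[C@@H](NC(=O)c2nc(Cc3ccccc3)n(CCCC#N)n2)COc2ccccc21` likewise gives only a limit, > 100000 nM. The three changes among them, a step that the two limits leave unreadable from compound 1 to compound 2, a step that the two limits leave unreadable from compound 1 to compound 3 and a step that the two limits leave unreadable from compound 2 to compound 3, therefore cannot be sized, since (the limit of > 100000 nM in this assay, at which 3 of the 3 values shown sit). Compound 4 `CN1C(=S)[C@@H](NC(=O)c2nc(Cc3ccccc3)n(C3CCC3)n2)COc2ccccc21` differs from compound 1 by cyclobutyl in place of propyl on an aromatic nitrogen. Going by the values given here, no measured step speaks to this change, and none of the measured compounds left the limit, so for compound 4 a step of a number no higher from compound 1 to compound 4 (the limit leaves the size open) is expected, that is, no change beyond the scatter. Compound 4 is expected to give about 100000 nM, within 50000 nM to 300000 nM, most likely again only as a limit.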

Compound 4, half-maximal cytotoxic concentration: > 100000 nM
Compound 4: only a limit was reported; the forecaster's own chance of this, stated with the estimate: 85%; the middle value lies on the limit itself.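

Going by these compounds alone, compound 4, like compound 1, compound 2 and compound 3, reaches only a limit in this assay, so no step to compound 4 can be read: the limit of > 100000 nM in this assay, at which 4 of the 4 values shown sit. The compounds shown leave open at what concentration any of them would become toxic to these cells.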